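Working notes: from compound 2 to compound 3

The source may hold more compounds than are shown below. What is called first, only, known or untested is meant among the compounds shown, and "the series" means these compounds.

In a functional assay on MCF7 cells (Homo sapiens) for inhibition, read by fluorescence, with a stated time of 72 h (a lower number here means a stronger inhibitor, a higher number a weaker inhibitor), compound 1 `CC(C)n1cnc2c(NC(=N)N)nc(NCCO)nc21` gives 12400 nM and compound 2 `CC[C@H](N)COc1nc(NC(=N)N)c2ncn(C(C)C)c2n1` gives 16300 nM. Among the measured compounds shown here, compound 2 therefore lies within the scatter of compound 1, the only other measured compound. The next change, leading to compound 3 `CC(C)[C@@H](CO)Nc1nc(NC(=N)N)c2ncn(C(C)C)c2n1`, is (1-(hydroxymethyl)-2-methylpropyl)amino in place of 2-aminobutoxy on an aromatic carbon, on an aromatic carbon between two ring nitrogen atoms. For the measured compounds named here, the one measured step that bears on it, a 1.3-fold higher number from compound 1 to compound 2 (0.12 log units; within the scatter), placed 2-aminobutoxy where (2-hydroxyethyl)amino stood. The expected step, a 1.3-fold lower number from compound 2 to compound 3 (0.10 log units; within the scatter), is therefore none beyond the scatter. Compound 3 is estimated at 13000 nM, with an expected range of 6000 nM to 30000 nM.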

Compound 3, half-maximal inhibitory concentration: 2100 nM
Beside the measured number, compound 3's estimate is 6.2-fold (0.79 log units) above it, and the stated range ends above it.
By their numbers in this assay, from the lowest: compound 3; then compounds 1 and 2 (each within the scatter of the next).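

At the aromatic carbon between two ring nitrogen atoms, this assay now shows a step beyond the scatter: (1-(hydroxymethyl)-2-methylpropyl)amino in place of 2-aminobutoxy gives a 7.8-fold lower number from compound 2 to compound 3 (0.89 log units; beyond the scatter). Isopropyl in place of hydrogen on the saturated chain carbon bound to the nitrogen gives a 5.9-fold lower number from compound 1 to compound 3 (0.77 log units; beyond the scatter), so this position responds to a change in the chain, which the earlier step within the scatter did not show. No measurement here explains either step.

Open, from the compounds shown here alone, is whether the isopropyl branch needs the hydroxymethyl group, which a simple alkylamine at this carbon would address. Also open, going by these compounds, is how a larger branch such as tert-butyl or a phenyl group on that chain carbon would read.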